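Solubility notes on the dichloro series, ahead of compound 3

A few compounds are considered here, and "the series" means these few. Any claim that something is new, unique, unknown or untested is made for them only; others in the source may bear on it.

Two compounds of this series have a number in a physicochemical assay for solubility, measured as kinetic solubility, with a stated time of 1 h, at pH 7.4; a lower number here means a less soluble compound, a higher number a more soluble compound. Compound 1, `CC(=O)Nc1nc(-c2cc(Cl)c(Cl)s2)cs1`, gives 1000 nM. Compound 2, `CC(=O)NC1=NN(c2ccc(Cl)c(Cl)c2)CC1`, gives 31000 nM in this assay, the higher of the two numbers, and the gap from compound 1 to compound 2 is beyond the scatter of repeated measurements. Within the data shown here, no stepwise pair differing in one place is available among the measured compounds, so nothing can be said about how single changes move this assay here.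

Compound 3, `O=C(NC1=NN(c2ccc(Cl)c(Cl)c2)CC1)c1ccncn1`, has not yet been measured. It differs from compound 2 as follows: pyrimidin-4-yl in place of methyl on a carbonyl carbon. Among the measured compounds shown here, with no measured step to lean on, the change is expected to lower the number in this assay by a step of moderate size, beyond the scatter, from compound 2 to compound 3: a 3.1-fold lower number from compound 2 to compound 3 (0.49 log units; beyond the scatter). Compound 3 is therefore estimated at 10000 nM, within a range from 2500 nM to 40000 nM.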

Compound 3, solubility: 13000 nM
Estimate against measurement, compound 3: 1.3-fold (0.11 log units) below, within the range that was stated.
By their numbers in this assay, from the lowest: compound 1; then compound 3; then compound 2.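

In this assay, the series now has its first step that differs in one place: pyrimidin-4-yl in place of methyl on a carbonyl carbon gives a 2.4-fold lower number from compound 2 to compound 3 (0.38 log units; beyond the scatter), which is modest in size. This position therefore carries a six-membered aromatic ring with 2 hetero atoms in place of a single methyl, and the number moves only by this modest step. No measurement at hand bears on the origin of this step.

This single step leaves open whether its size follows from the aromatic ring itself or from the ring nitrogens, a question that phenyl on the same carbonyl carbon would address. Also open, going by these compounds, is how a carboxylic acid or a longer chain ending in an amine would register at this place.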